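Removing the methyl from compound 3's aryl ring

This account rests on a few compounds, and the source may have more. Where it says the series, first, only, none or still open, it means among the compounds named here.

Measured so far:
compound 1 `O=C(Nc1cccc2[nH]ncc12)NC1CCOc2c(OC(F)(F)F)cccc21` gives 5 nM
compound 2 `O=C(Nc1cccc2[nH]ncc12)NC1CCOc2c1cccc2N1CCCCC1` gives 16 nM
compound 3 `Cc1ccc2c(c1)C(NC(=O)Nc1cccc3[nH]ncc13)CCO2` gives 933 nM

In a functional assay for antagonist activity at transient receptor potential cation channel subfamily V member 1 (Homo sapiens), read by calcium flux (on this read-out lower numbers stand for stronger inhibition and higher numbers for weaker inhibition), compound 3 stands at the highest of the three numbers: compound 2 sits at a lower number, and compound 1 at a lower one still, both gaps beyond the scatter. Compound 4 `O=C(Nc1cccc2[nH]ncc12)NC1CCOc2ccccc21` differs from compound 3 by hydrogen in place of methyl on an aromatic carbon. Going by the values given here, the one measured step, a 3.2-fold higher number from compound 1 to compound 2 (0.51 log units; beyond the scatter), swaps one group for another and concerns neither a methyl nor its removal, so it bears on the present change only loosely; it does show that the shared core tolerates sizeable variation of an aryl substituent while staying potent. Among the compounds with values here, no measured step removes a group outright, so the direction of the present change is open. Compound 4 is expected to give roughly 400 nM, somewhere between 80 nM and 3000 nM, which would mean an expected step of a 2.3-fold lower number from compound 3 to compound 4 (0.37 log units; beyond the scatter).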

Compound 4, half-maximal inhibitory concentration: 234 nM
Beside the measured number, compound 4's estimate is 1.7-fold (0.23 log units) above it; measured number inside the range.
By their numbers in this assay, from the lowest: compound 1; then compound 2; then compound 4; then compound 3.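

In this assay, a 4.0-fold lower number from compound 3 to compound 4 (0.60 log units; beyond the scatter), so the methyl on this aromatic carbon, meta to a fused ring and para to a fused ring, goes with weaker inhibition than hydrogen does. Compound 4 also gives the shared core a reference with no aryl substituent, and the other two steps run the opposite way: a 15-fold higher number from compound 2 to compound 4 (1.17 log units; beyond the scatter) and a 47-fold higher number from compound 1 to compound 4 (1.67 log units; beyond the scatter), with piperidin-1-yl and trifluoromethoxy each sitting on a different aromatic carbon from the methyl. Among these three groups, only methyl gives a higher number than hydrogen, so an aryl substituent does not favour inhibition in every case.

Going by these compounds, whether this reflects the group or its place stays open, as would be tested by a methyl on the carbon bearing trifluoromethoxy, or by trifluoromethoxy, chlorine or an amine on the methyl's carbon. No measurement shown accounts for these differences.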